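Cyclopentyl to Isopropyl: A Forecast for Compound 4

The source may report more compounds than this note shows. Statements on the series, on what has been measured and on what is new or still open speak of the compounds shown alone.

Compound 1, `Cc1c(OCCCCOc2ccc(C(=O)O)cc2)ccc(C(=O)CC(C)C)c1O`, gives 66% in an ADME assay (liver) for metabolic stability, with Liver microsome (Rattus norvegicus) as the target, read by LC-MS, using microsomes and NADPH, with stated times of 5 min and 60 min, tested at 4 uM; on this read-out higher numbers stand for a more stable compound and lower numbers for a less stable compound.
Compound 2, `COc1ccc(C(=O)O)cc1OCCCCOc1ccc(C(=O)CC(C)C)c(O)c1C`, gives 5% in this assay.
Compound 3, `Cc1ccc(C(=O)O)cc1OCCCCOc1ccc(C(=O)CC2CCCC2)c(O)c1C`, gives 9% in this assay.

Compound 3 stands second highest of the three numbers. Its nearest neighbour is compound 2, whose value lies within the scatter of compound 3, so the two cannot be told apart. The furthest is compound 1, which lies well beyond the scatter above compound 3; compound 1 also carries a benzoic acid ring without the further substituent seen in compounds 2 and 3.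

Compound 4, `Cc1ccc(C(=O)O)cc1OCCCCOc1ccc(C(=O)CC(C)C)c(O)c1C`, has not yet been measured in this assay. It differs from compound 3 in one place: isopropyl in place of cyclopentyl on a saturated chain carbon bound to a carbonyl carbon. Compound 4 thus shares the acid ring of compound 3 and the isobutylcarbonyl of compounds 1 and 2.

Within the data shown here, no measured pair shows this exact change. Since compounds 2 and 3, which both carry a substituted acid ring, sit low and close together, compound 4 is expected to remain in the same low region, with a modest rise a number 9 percentage points higher from compound 3 to compound 4 (within the scatter) that may not exceed the scatter. Compound 4 is estimated at 18%, within 5% to 45%.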

Compound 4, percent of the compound remaining: 21%
For compound 4 the middle estimate is 3 percentage points below the measured one; measured number inside the range.
By their numbers in this assay, from the lowest: compounds 2 and 3 (each within the scatter of the next); then compound 4; then compound 1.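

In this assay, among these compounds, isopropyl in place of cyclopentyl on a saturated chain carbon bound to a carbonyl carbon gives a number 12 percentage points higher from compound 3 to compound 4 (beyond the scatter), the first reading of a change at this position, and it shows that the group carried there matters on this core. The two aromatic positions also count, since methyl in place of methoxy on an aromatic carbon gives a number 16 percentage points higher from compound 2 to compound 4 (beyond the scatter), while 5-carboxy-2-methylphenyl in place of 4-carboxyphenyl on an oxygen on a saturated carbon gives a number 45 percentage points lower from compound 1 to compound 4 (beyond the scatter), so the acid ring carries the large step and the other two changes carry modest ones. The data offer nothing that accounts for any of these steps.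

The compounds shown leave open whether the step from cyclopentyl to isopropyl would have the same size on the unsubstituted acid ring of compound 1 or on the methoxy ring of compound 2. They also leave open how a cyclopropyl or tert-butyl group would read at the chain position, and how a primary amide would read in place of the carboxylic acid.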